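This account rests on a few compounds, and the source may have more. Where it says the series, first, only, none or still open, it means among the compounds named here.

Measured in a functional assay on A549 cells (Homo sapiens) for inhibition, read by CCK-8 assay, with a stated time of 72 h, tested at 1 uM; on this read-out lower numbers stand for less inhibition of growth and higher numbers for more inhibition of growth at the one concentration tested:
compound 1 (`CN(C)C(=O)c1cc2cnc(Nc3ccc(NC(=O)C4(C(=O)Nc5cccc(Cl)c5)CC4)cc3)nc2n1C1CCCC1`) gives 8.3%
compound 2 (`CN(C)C(=O)c1cc2cnc(Nc3ccc(NC(=O)C4(C(=O)Nc5ccc(Br)cc5)CC4)cc3)nc2n1C1CCCC1`) gives -6.6%
compound 3 (`COc1cccc(NC(=O)C2(C(=O)Nc3ccc(Nc4ncc5cc(C(=O)N(C)C)n(C6CCCC6)c5n4)cc3)CC2)c1`) gives 77.2%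

Compound 3 stands highest of the three, and large steps lead up to it (a number 68.9 percentage points higher from compound 1 to compound 3 (beyond the scatter) and a number 83.8 percentage points higher from compound 2 to compound 3 (beyond the scatter)). The step between the other two is modest (a number 14.9 percentage points lower from compound 1 to compound 2 (beyond the scatter)). Next is compound 4 (`CN(C)C(=O)c1cc2cnc(Nc3ccc(NC(=O)C4(C(=O)Nc5ccc(O)cc5)CC4)cc3)nc2n1C1CCCC1`), with 4-hydroxyphenyl in place of 3-methoxyphenyl on an amide-type nitrogen. Among the compounds with values here, no measured compound carries a hydroxy group, so the evidence is indirect. Among these three compounds, only the one with 3-methoxyphenyl gives high inhibition in this assay. Within the data shown here, the closest comparison is compound 2 (-6.6%), the only other compound with a group named at the 4 position of the phenyl, and it lies far lower. A large fall is therefore expected, though with wide uncertainty, as the expected step is a number 52.2 percentage points lower from compound 3 to compound 4 (beyond the scatter) in this assay. Compound 4 is estimated at 25% (expected range -5% to 70%).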

Compound 4, percent growth inhibition at one concentration: 93.6%
Compound 4: middle estimate off by 68.6 percentage points, on the low side; measured number outside the range, above it.
By their numbers in this assay, from the lowest: compound 2; then compound 1; then compound 3; then compound 4.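

On the amide-type nitrogen, high inhibition in this assay is not confined to 3-methoxyphenyl: 4-hydroxyphenyl also reaches it, with a number 16.4 percentage points higher from compound 3 to compound 4 (beyond the scatter). A group on the 4 position of this phenyl is therefore not enough to lower the number, since hydroxy in place of bromo on an aromatic carbon gives a number 100.2 percentage points higher from compound 2 to compound 4 (beyond the scatter), and 4-hydroxyphenyl in place of 3-chlorophenyl gives a number 85.3 percentage points higher from compound 1 to compound 4 (beyond the scatter). Across these four compounds, the two oxygen-bearing groups stand high and the two halogen-bearing groups low, and no measurement at hand accounts for this split.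

It remains open whether the result follows the oxygen itself or its place on the phenyl, as 3-hydroxyphenyl and 4-methoxyphenyl are not among the compounds shown. From the compounds shown here alone, how a 4-aminophenyl or a 4-carboxyphenyl would read in this assay is also open.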